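Swapping the styryl arm for a methoxyphenyl ring

The source may report more compounds than this note shows. Statements on the series, on what has been measured and on what is new or still open speak of the compounds shown alone.

Compound 1: `CC(C)(C)Cc1csc(N)c1C(=O)c1ccc(Cl)cc1`, 5%
Compound 2: `CC(C)(C)Cc1c(-c2ccc(F)cc2)sc(N)c1C(=O)c1ccc(Cl)cc1`, 9%
Compound 3: `CC(C)(C)Cc1c(/C=C/c2ccc(Cl)cc2)sc(N)c1C(=O)c1ccc(Cl)cc1`, 11%

In an assay on CHO cells for displacement of a labelled ligand from adenosine receptor A3 (Homo sapiens), read by scintillation counting, tested at 10 uM (on this read-out higher numbers stand for more inhibition at the one concentration tested (going by the name of the read-out) and lower numbers for less inhibition), all three numbers lie close together. Compound 3 is separated from its neighbours by a number 2 percentage points higher from compound 2 to compound 3 (within the scatter) and by a number 6 percentage points higher from compound 1 to compound 3 (within the scatter), so it cannot be told apart from compound 1 or compound 2. Compound 4, `COc1cccc(-c2sc(N)c(C(=O)c3ccc(Cl)cc3)c2CC(C)(C)C)c1`, differs from compound 3 in one place: 3-methoxyphenyl in place of 2-(4-chlorophenyl)ethenyl on an aromatic carbon. The nearest guide is compound 2, where a 4-fluorophenyl group sits in the same place; there a number 4 percentage points higher from compound 1 to compound 2 (within the scatter), and a number 2 percentage points higher from compound 2 to compound 3 (within the scatter) also stayed within the scatter. Changing this group has so far left this assay unmoved, so compound 4 is expected to show a number 2 percentage points lower from compound 3 to compound 4 (within the scatter). For compound 4 the estimate is 9%, expected to fall between 0% and 20%.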

Compound 4, a percentage reported as inhibition, at one concentration (the size of the read-out at that concentration, not a potency): 1%
Compound 4: the middle estimate sits 8 percentage points above what was measured, and the stated range covers the measured number.
By their numbers in this assay, from the lowest: compounds 4, 1, 2 and 3 (each within the scatter of the next).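

With 3-methoxyphenyl on the carbon next to the ring sulfur, this assay gives a number 10 percentage points lower from compound 3 to compound 4 (within the scatter) and a number 8 percentage points lower from compound 2 to compound 4 (within the scatter) and also a number 4 percentage points lower from compound 1 to compound 4 (within the scatter) as its three comparisons. A ring carrying a hydrogen-bond acceptor therefore cannot be told apart here from the 2-(4-chlorophenyl)ethenyl group, the 4-fluorophenyl group or plain hydrogen. No measurement is available that explains this flat result. Still open, as far as these compounds go, is whether an amine or a carboxylic acid on this carbon would give a clearly different number. Equally open, from the compounds shown here alone, is whether replacing the neopentyl group would.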